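Alkyl growth on the shared core: compound 3 to compound 4

A few compounds are considered here, and "the series" means these few. Any claim that something is new, unique, unknown or untested is made for them only; others in the source may bear on it.

Compound 3 `COc1cc2nc(C(C)C)nc(N3CCN(c4ccccc4OC)CC3)c2cc1OC` reaches only a limit in an in vitro assay on U2OS cells for agonist activity at neurotensin receptor type 2 (Homo sapiens), read by reporter gene assay and beta-arrestin recruitment; on this read-out lower numbers stand for an effect already at smaller amounts and higher numbers for an effect only at larger amounts of compound: compound 3 gives > 80000 nM, a limit of the assay and not a number. Compound 1 `COc1cc2ncnc(N3CCN(c4ccccc4OC)CC3)c2cc1OC` likewise sits at a limit, giving > 80000 nM. Compound 2 `CCCc1nc(N2CCN(c3ccccc3OC)CC2)c2cc(OC)c(OC)cc2n1` also sits at a limit, giving > 80000 nM. All three values rest on the same limit (the limit of > 80000 nM in this assay, at which 3 of the 3 values shown sit), so the steps a step that the two limits leave unreadable from compound 1 to compound 2, a step that the two limits leave unreadable from compound 1 to compound 3 and a step that the two limits leave unreadable from compound 2 to compound 3 are of unreadable size. Compound 4 `COc1cc2nc(CC(C)C)nc(N3CCN(c4ccccc4OC)CC3)c2cc1OC` differs from compound 3 by isobutyl in place of isopropyl on an aromatic carbon. The measured steps bear on this change only in that no alkyl group so far has moved the series off the limit. The step that the limit leaves unreadable from compound 3 to compound 4 is therefore expected to remain unreadable. Compound 4 is expected at 100000 nM, with a range of 40000 nM to 300000 nM.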

Compound 4, half-maximal effective concentration: > 80000 nM
Compound 4 gave a limit, no number; the forecaster's own chance of this, stated with the estimate: 85%; the middle value does not contradict the limit.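

Compound 4, like compound 1, compound 2 and compound 3, gives a limit and not a number, so no new step among them can be read: the limit of > 80000 nM in this assay, at which 4 of the 4 values shown sit.

The compounds shown leave open what size of effect, if any, these alkyl groups have on the shared core.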